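Side-chain variation on the shared lactone core

A few compounds are considered here, and "the series" means these few. Any claim that something is new, unique, unknown or untested is made for them only; others in the source may bear on it.

The compounds share the core of compound 1 `Cc1ccc(-c2cn(C/C=C3\OC(=O)C(OCc4ccccc4)=C3OCc3ccccc3)nn2)cc1` and differ in the substituent carried on the side chain and in the linker to it. In a functional assay on HeLa cells (Homo sapiens) for antiproliferative activity, read by MTT assay, with a stated time of 72 h (on this read-out lower numbers stand for stronger inhibition and higher numbers for weaker inhibition), compound 1 gives 7480 nM. Compound 2 `CCCCc1cn(C[C@H](O)[C@H]2OC(=O)C(OCc3ccccc3)=C2OCc2ccccc2)nn1` has a butyl substituent and a hydroxylated linker; in this assay compound 2 gives 18100 nM, the highest of the two numbers shown, with compound 1 the nearest and lower by a step that lies beyond the usual scatter. For compound 3 `O=C1O/C(=C\Cn2cc(-c3cc(C(F)(F)F)cc(C(F)(F)F)c3)nn2)C(OCc2ccccc2)=C1OCc1ccccc1` the result in this assay is a limit of the assay and not a number, > 100000 nM; this is the case noted as the limit of > 100000 nM in this assay, at which 1 of the 3 values shown sits.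

Compound 4 `O=C1O[C@H]([C@@H](O)Cn2cc(CNS(=O)(=O)c3ccc(Cl)cc3)nn2)C(OCc2ccccc2)=C1OCc1ccccc1` is not yet measured. It differs from compound 2 in one place: ((4-chlorophenyl)sulfonyl)amino in place of propyl on a saturated chain carbon bound to an aromatic carbon. Within the data shown here, no pair of measured compounds shows this change, so its effect in this assay cannot be read from the series. The step from compound 2 to compound 4 is expected to be a 1.2-fold lower number from compound 2 to compound 4 (0.08 log units; within the scatter), with no clear direction and likely not beyond the scatter. Compound 4 is therefore estimated at 15000 nM in this assay, within a range from 4000 nM to 60000 nM.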

Compound 4, half-maximal inhibitory concentration: 13600 nM
Compound 4: the middle estimate sits 1.1-fold (0.04 log units) above what was measured, and the stated range covers the measured number.
By their numbers in this assay, from the lowest: compounds 1, 4 and 2 (each within the scatter of the next, the first and the last beyond it). At a limit, above all of these: compound 3.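

In this assay, ((4-chlorophenyl)sulfonyl)amino in place of propyl on a saturated chain carbon bound to an aromatic carbon gives a 1.3-fold lower number from compound 2 to compound 4 (0.12 log units; within the scatter), the first single-place comparison available in the series. The entering group brings a six-membered aromatic ring, a sulfur, a chlorine, a hydrogen-bond donor and hydrogen-bond acceptors that propyl lacks, yet the two numbers lie within the scatter of each other, so at this position, and for this pair alone, an all-carbon chain end and this far larger end cannot be told apart by this read-out. No measurement shown bears on the reason for this result.

Open, on these data alone, is whether the sulfonylamino link or the 4-chlorophenyl ring counts more in this group, which a plain amine, a carboxylic acid or an unchlorinated phenylsulfonylamino group at the same place would help to separate. Also open, as far as these compounds go, is what the hydroxylated linker contributes on its own, as compound 1 and compound 3 each differ from compound 2 and compound 4 in more than one place.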